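Hydrogen for fluoro: from compound 2 to compound 3

The source may hold more compounds than are shown below. What is called first, only, known or untested is meant among the compounds shown, and "the series" means these compounds.

Compound 2 `Cc1ccc(-c2nc3ccc(F)cc3s2)cc1N` gives in a functional assay on Jurkat cells (Homo sapiens) for cytotoxicity, read by MTT assay, with a stated time of 2 days (on this read-out lower numbers stand for stronger inhibition and higher numbers for weaker inhibition), a value of > 50000 nM, which is a limit of the assay and not a number. Compound 1 `COc1ccc2nc(-c3ccc(C)c(N)c3)sc2c1` likewise gives > 50000 nM, also a limit. The step that the two limits leave unreadable from compound 1 to compound 2 is therefore unreadable, since (the limit of > 50000 nM in this assay, at which 2 of the 2 values shown sit). Compound 3 `Cc1ccc(-c2nc3ccccc3s2)cc1N` differs from compound 2 by hydrogen in place of fluoro on an aromatic carbon. Within the data shown here, no measured step bears readably on this change. The expected step is a step that the limit leaves unreadable from compound 2 to compound 3, nothing beyond the scatter. For compound 3 the estimate is 80000 nM, with a range from 30000 nM to 250000 nM, most likely reported again as a limit.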

Compound 3, half-maximal inhibitory concentration: > 50000 nM
Compound 3: no number, only a limit (the forecaster's own chance of this, stated with the estimate: 85%); the middle value does not contradict the limit.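

Among these compounds, no step among compound 1, compound 2 and compound 3 can be read in this assay because each value is a limit of the assay, not a number: the limit of > 50000 nM in this assay, at which 3 of the 3 values shown sit. The compounds shown leave open whether methoxy, fluoro or hydrogen on this aromatic carbon differ at all in this read-out.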